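Compound 4: a chlorophenyl swap in a series at the limit

The source may hold more compounds than are shown below. What is called first, only, known or untested is meant among the compounds shown, and "the series" means these compounds.

Measured in a functional assay on K562 cells (Homo sapiens) for antiproliferative activity, read by MTT assay, with a stated time of 24 h; a higher number here means a weaker inhibitor, a lower number a stronger inhibitor:
- compound 1 `COc1ccc(C(=O)/C=C/c2ccc(F)cc2)c2c1C=CC(C)(C)O2`: > 10000 nM (a limit)
- compound 2 `COc1ccc(C(=O)/C=C/c2ccccc2)c2c1C=CC(C)(C)O2`: > 10000 nM (a limit)
- compound 3 `COc1ccc(C(=O)/C=C/c2ccco2)c2c1C=CC(C)(C)O2`: > 10000 nM (a limit)

Compound 3 gives only a limit and no number. The same holds for the other two measured compounds, as the limit of > 10000 nM in this assay, at which 3 of the 3 values shown sit, shows, so no order among them can be read.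

The next compound is the unmeasured compound 4 `COc1ccc(C(=O)/C=C/c2ccccc2Cl)c2c1C=CC(C)(C)O2` of this series. The structural change is 2-chlorophenyl in place of furan-2-yl on a double-bonded chain carbon bound to a double-bonded chain carbon and the rest of the structure stays the same.

The closest evidence is a step that the two limits leave unreadable from compound 2 to compound 3 and a step that the two limits leave unreadable from compound 1 to compound 3 at the same place. A further step is a step that the two limits leave unreadable from compound 1 to compound 2 on the phenyl ring. None of these has a readable size, so none supplies a size or direction to carry over. A step beyond the scatter is therefore not expected, and another limit is the likeliest result.

The expected step is a step that the limit leaves unreadable from compound 3 to compound 4 with no firm direction. For compound 4 the estimated value is 12000 nM with an expected range from 5000 nM to 30000 nM in this assay here.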

Compound 4, half-maximal inhibitory concentration: > 10000 nM
Compound 4 gave a limit, no number; the forecaster's own chance of this, stated with the estimate: 75%; the middle value lies beyond the limit too.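

Compound 4 gives only a limit, so no step linking it to compound 1, compound 2 or compound 3 can be read, and the series stays unordered: the limit of > 10000 nM in this assay, at which 4 of the 4 values shown sit.

The compounds shown leave open whether any change on the shared core would give a readable value.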